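A few compounds are considered here, and "the series" means these few. Any claim that something is new, unique, unknown or untested is made for them only; others in the source may bear on it.

The measured compounds:

Compound 1, `CC1(C)[C@H]2CC[C@]1(C)N(Cc1cn(-c3cccc(Cl)c3)nn1)C(=O)C2`, in a functional assay on LoVo cells (Homo sapiens) for inhibition, read by MTT assay, with a stated time of 24 h (on this read-out lower numbers stand for stronger inhibition and higher numbers for weaker inhibition), gives 70 nM.
Compound 2, `Cc1ccccc1-n1cc(CN2C(=O)C[C@@H]3CC[C@@]2(C)C3(C)C)nn1`, in this assay gives 80 nM.
Compound 3, `COc1ccccc1-n1cc(CN2C(=O)C[C@@H]3CC[C@@]2(C)C3(C)C)nn1`, in this assay gives 70 nM.

On these numbers compound 3 stands level with compound 1, the two together giving the lowest numbers of the three, and its gap to compound 2, a 1.1-fold lower number from compound 2 to compound 3 (0.06 log units; within the scatter), lies within the scatter. Compound 4, `CC1(C)[C@H]2CC[C@]1(C)N(Cc1cn(-c3ccccc3)nn1)C(=O)C2`, differs from compound 3 in one place: hydrogen in place of methoxy on an aromatic carbon.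

Going by the values given here, the steps that bear on this change are those at the same aryl group: no change at the digits printed from compound 1 to compound 3 (within the scatter) and a 1.1-fold higher number from compound 1 to compound 2 (0.06 log units; within the scatter). Both are within the scatter, so the substituent on that ring has so far made no difference that can be told from repeat measurement. For compound 4 no step beyond the scatter is therefore expected in this assay, in either direction. Compound 4 is estimated at 75 nM, with a range from 40 nM to 150 nM, the expected step being a 1.1-fold higher number from compound 3 to compound 4 (0.03 log units; within the scatter).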

Compound 4, half-maximal inhibitory concentration: 50 nM
Compound 4: middle estimate off by 1.5-fold (0.18 log units), on the high side, and the stated range covers the measured number.
By their numbers in this assay, from the lowest: compounds 4, 1, 3 and 2 (each within the scatter of the next).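

With the bare phenyl compound added, the comparison in this assay now includes a ring carrying no substituent at all, and hydrogen in place of each earlier group gives three steps (a 1.4-fold lower number from compound 3 to compound 4 (0.15 log units; within the scatter)) and (a 1.6-fold lower number from compound 2 to compound 4 (0.20 log units; within the scatter)) and (a 1.4-fold lower number from compound 1 to compound 4 (0.15 log units; within the scatter)) that all lie within the scatter. Removing the methoxy, the methyl or the chloro therefore gives no difference that can be told from repeat measurement, so on these four compounds the substituent on this aromatic ring has shown no measurable effect on the read-out. No evidence is available that bears on this result.

The compounds shown leave open whether an amine or a carboxylic acid on this ring would give a step beyond the scatter in this assay on the same core. They also leave open whether a longer chain in place of the methoxy would do so.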